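This account rests on a few compounds, and the source may have more. Where it says the series, first, only, none or still open, it means among the compounds named here.

Compound 1 `O[C@@H](c1ccccc1)[C@H]1CO[C@H](c2ccccc2)[C@@H](C/C=C/c2ccncc2)C1`: > 100000 nM
Compound 2 `O[C@@H](c1ccccc1)[C@H]1CO[C@H](c2ccccc2)[C@@H](C/C=C/c2cccnc2)C1`: > 100000 nM
Compound 3 `O=[N+]([O-])c1ccc(/C=C/C[C@H]2C[C@@H]([C@@H](O)c3ccccc3)CO[C@@H]2c2ccccc2)cc1`: 12400 nM

In a functional assay on HeLa cells (Homo sapiens) for cytotoxicity, read by WST assay, with a stated time of 48 h (on this read-out higher numbers stand for weaker inhibition and lower numbers for stronger inhibition), compound 1 reaches only a limit, > 100000 nM. Compound 2 likewise reaches only a limit, > 100000 nM. Among the measured compounds shown here, compound 3 gives 12400 nM, the only number among the three. Compounds 1 and 2 sit at the limit (the limit of > 100000 nM in this assay, at which 2 of the 3 values shown sit). The measured steps are an at least 8.0-fold lower number from compound 1 to compound 3 (0.90 log units; beyond the scatter) and an at least 8.0-fold lower number from compound 2 to compound 3 (0.90 log units; beyond the scatter); the step that the two limits leave unreadable from compound 1 to compound 2 is unreadable.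

Compound 4 `O[C@@H](c1ccccc1)[C@H]1CO[C@H](c2ccccc2)[C@@H](C/C=C/c2ccccc2F)C1` differs from compound 3 by 2-fluorophenyl in place of 4-nitrophenyl on a double-bonded chain carbon bound to a double-bonded chain carbon. For the measured compounds named here, no measured step touches a 2-fluorophenyl, so the measured steps bear on it only loosely. Compound 4 is therefore expected to sit near compound 3 or somewhat weaker, with a 2.0-fold higher number from compound 3 to compound 4 (0.30 log units; within the scatter) as the expected step. The estimate for compound 4 is 25000 nM, within 8000 nM to 100000 nM.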

Compound 4, half-maximal inhibitory concentration: 9730 nM
Compound 4: middle estimate off by 2.6-fold (0.41 log units), on the high side; the range from low to high includes it.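

At the double-bonded chain carbon, replacing 4-nitrophenyl with 2-fluorophenyl gives a 1.3-fold lower number from compound 3 to compound 4 (0.11 log units; within the scatter), so the nitro group is not needed for the read-out seen with compound 3. The same replacement set against the pyridinyl groups gives an at least 10-fold lower number from compound 2 to compound 4 (1.01 log units; beyond the scatter) and an at least 10-fold lower number from compound 1 to compound 4 (1.01 log units; beyond the scatter), so a second phenyl compound now separates from both pyridinyl compounds. These two steps are only bounds, because each starts from a limit: the limit of > 100000 nM in this assay, at which 2 of the 4 values shown sit.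

The compounds shown leave open whether an unsubstituted phenyl or a 4-methoxyphenyl at this carbon would read the same. They also leave open whether 4-fluorophenyl would match 2-fluorophenyl.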